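Swapping bromo for chloro on the phenyl triazole series

The source may report more compounds than this note shows. Statements on the series, on what has been measured and on what is new or still open speak of the compounds shown alone.

Compound 1 `CC1(C)[C@H]2CC[C@]1(C)N(Cc1cn(-c3cccc(Cl)c3)nn1)C(=O)C2`: 60 nM
Compound 2 `CC1(C)[C@H]2CC[C@]1(C)N(Cc1cn(-c3ccccc3)nn1)C(=O)C2`: 70 nM
Compound 3 `CC1(C)[C@H]2CC[C@]1(C)N(Cc1cn(-c3ccc(Br)cc3)nn1)C(=O)C2`: 80 nM

In a functional assay on A549 cells (Homo sapiens) for inhibition, read by MTT assay, with a stated time of 24 h (a lower number here means a stronger inhibitor, a higher number a weaker inhibitor), compound 3 gives 80 nM, a number not separated from its two neighbours: a 1.1-fold higher number from compound 2 to compound 3 (0.06 log units; within the scatter), and a 1.3-fold higher number from compound 1 to compound 3 (0.12 log units; within the scatter). Compound 4 `CC1(C)[C@H]2CC[C@]1(C)N(Cc1cn(-c3ccc(Cl)cc3)nn1)C(=O)C2` differs from it by one atom: chloro in place of bromo on an aromatic carbon. For the measured compounds named here, two measured steps bear on this. Bromo in place of hydrogen gave a 1.1-fold higher number from compound 2 to compound 3 (0.06 log units; within the scatter), and hydrogen in place of chloro gave a 1.2-fold higher number from compound 1 to compound 2 (0.07 log units; within the scatter). Neither clears the scatter, so no step beyond it is expected here. The expected step is a 1.1-fold lower number from compound 3 to compound 4 (0.05 log units; within the scatter). For compound 4 the estimated value is 72 nM, with an expected range of 40 nM to 130 nM.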

Compound 4, half-maximal inhibitory concentration: 70 nM
Estimate against measurement, compound 4: 1.0-fold (0.01 log units) above; measured number inside the range.
By their numbers in this assay, from the lowest: compounds 1, 2, 4 and 3 (each within the scatter of the next).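

In this assay, the swap on the aromatic carbon para to a large group stays within the scatter, whether chloro replaces bromo (a 1.1-fold lower number from compound 3 to compound 4 (0.06 log units; within the scatter)) or chloro replaces hydrogen (no change at the digits printed from compound 2 to compound 4 (within the scatter)). The 4-chlorophenyl and 3-chlorophenyl groups also do not separate (a 1.2-fold higher number from compound 1 to compound 4 (0.07 log units; within the scatter)), so among these four compounds neither the identity of the halogen nor these two chloro placements is resolved by this read-out. No measured evidence accounts for this flat picture.

On these data alone, whether an amine or a carboxylic acid at this place would give a step beyond the scatter remains open.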